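A few compounds are considered here, and "the series" means these few. Any claim that something is new, unique, unknown or untested is made for them only; others in the source may bear on it.

In a functional assay on HeLa cells (Homo sapiens) for antiproliferative activity, read by MTT assay, with a stated time of 48 h (on this read-out higher numbers stand for weaker inhibition and lower numbers for stronger inhibition), compound 1 `CN(C)CCCn1c(N)c(-c2nc3ccccc3n2C)c2nc(C#N)c(C#N)nc21` gives 4320 nM as a measured number. Compound 2 `CCN(CC)CCn1c(N)c(-c2nc3cc(Cl)ccc3[nH]2)c2nc(C#N)c(C#N)nc21` stands at > 50000 nM which is a limit of the assay and not a number. Compound 3 `CN(C)CCCn1c(N)c(-c2nc3cc(Cl)ccc3[nH]2)c2nc(C#N)c(C#N)nc21` is still unmeasured and carries (dimethylamino)methyl in place of diethylamino on a saturated chain carbon, two bonds along the chain from an aromatic nitrogen, the full difference being (dimethylamino)methyl in place of diethylamino on a saturated chain carbon, two bonds along the chain from an aromatic nitrogen and nothing more. Within the data shown here, with compound 1 at 4320 nM as the only measured number, stronger inhibition beyond the usual scatter is expected. The expected change an at least 4.1-fold lower number from compound 2 to compound 3 (0.61 log units; beyond the scatter) is only an estimate. For compound 3 the estimated value is 12000 nM with 3000 nM to 50000 nM as its likely range.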

Compound 3, half-maximal inhibitory concentration: 16500 nM
Estimate against measurement, compound 3: 1.4-fold (0.14 log units) below; measured number inside the range.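

In this assay, 3-(dimethylamino)propyl in place of 2-(diethylamino)ethyl gives an at least 3.0-fold lower number from compound 2 to compound 3 (0.48 log units; beyond the scatter), showing that this side chain matters when the 5-chloro-1H-benzimidazol-2-yl group stays fixed. Compound 2 stands at a limit of the assay and not a number, so this step is only a minimum: the limit of > 50000 nM in this assay, at which 1 of the 3 values shown sits.

With the side chain fixed, the benzimidazole change gives a 3.8-fold higher number from compound 1 to compound 3 (0.58 log units; beyond the scatter), so that group matters too.

Chain length and the amine's alkyl groups change together, leaving their separate contributions open. A 3-(diethylamino)propyl chain would help separate them, and a morpholine at the chain end would test a ring amine.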